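The source may hold more compounds than are shown below. What is called first, only, known or untested is meant among the compounds shown, and "the series" means these compounds.

Measured in a functional assay on cells (Tumor Cell line, Homo sapiens) for antiproliferative activity; a lower number here means a stronger inhibitor of growth, a higher number a weaker inhibitor of growth:
- Compound 1 `Cc1cc(C)c2c(O)cc(-c3cccc(F)c3)nc2n1`: 85.1 nM
- Compound 2 `Cc1ccnc2nc(-c3ccc4ccccc4c3)cc(O)c12`: 1200 nM

Of these two compounds, compound 2 has the higher number and is therefore the weaker inhibitor of growth, with a gap to compound 1 that lies beyond the scatter. Compound 3 `Cc1cc(C)c2c(O)cc(-c3ccc4ccccc4c3)nc2n1` differs from compound 2 in one place: methyl in place of hydrogen on an aromatic carbon. This is a methyl in place of hydrogen on an aromatic carbon, next to the ring nitrogen. Compound 3 thus has the core of compound 1 and keeps the remaining group of compound 2.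

For the measured compounds named here, compounds 1 and 2 differ in more than one place, and no measured pair isolates this methyl, so the gap between them cannot be assigned to it. Part of that gap may belong to the methyl, but the group that compound 3 keeps from compound 2 may account for much of it. A modest move toward stronger inhibition in this assay is therefore expected, and no change beyond the scatter remains possible. The expected step is a 2.0-fold lower number from compound 2 to compound 3 (0.30 log units; within the scatter). For compound 3 the estimate is 600 nM, with an expected range from 170 nM to 2200 nM.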

Compound 3, concentration for 50% growth inhibition: 13500 nM
The estimate for compound 3 lay 23-fold (1.35 log units) below the measured number, and the stated range ends below it.
By their numbers in this assay, from the lowest: compound 1; then compound 2; then compound 3.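

At this position the change is far from neutral: a methyl in place of hydrogen on an aromatic carbon, next to the ring nitrogen, gives an 11-fold higher number from compound 2 to compound 3 (1.05 log units; beyond the scatter) in this assay, and so a clear loss of growth inhibition. The core of compound 1 therefore does not carry strong inhibition by itself, since compound 1 gives 85.1 nM while compound 3, with the same core and a different remaining group, gives 13500 nM and is the weakest of the three by its printed number. Nothing available explains why this methyl costs so much in the setting of compound 3.

The compounds shown leave open whether the same methyl would cost as much alongside the remaining group of compound 1, as no pair isolates it there. They also leave open how this aromatic carbon would respond to a different group, such as an ethyl, a methoxy or an amine, and whether the loss is particular to methyl or follows from any group placed there.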